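The source may report more compounds than this note shows. Statements on the series, on what has been measured and on what is new or still open speak of the compounds shown alone.

Compound 1 `C#CCSc1nc(Nc2ccc(OC)cc2)c(C#N)c(-c2ccccc2)n1`: 9710 nM
Compound 2 `C#CCSc1nc(Nc2ccccc2Cl)c(C#N)c(-c2ccccc2)n1`: 12400 nM
Compound 3 `N#Cc1c(Nc2cccc(Cl)c2)nc(SCc2cn(Cc3ccccc3Cl)nn2)nc1-c1ccccc1`: 3590 nM

These three compounds share a common core and were all tested in a functional assay on B16-F10 cells (Mus musculus) for inhibition, read by MTT assay, with a stated time of 72 h; a lower number here means a stronger inhibitor, a higher number a weaker inhibitor. Compound 3 gives the lowest number of the three, 3590 nM; the nearest to it is compound 1, and the gap between them is beyond the usual scatter, so compound 3 counts as the strongest inhibitor of the set. Compound 4 `Cc1ccc(Nc2nc(SCc3cn(Cc4ccccc4Cl)nn3)nc(-c3ccccc3)c2C#N)cc1` has not been measured yet. It differs from compound 3 in one place: 4-methylphenyl in place of 3-chlorophenyl on a nitrogen on an aromatic ring. Among the compounds with values here, only one measured step swaps the group on this nitrogen: a 1.3-fold higher number from compound 1 to compound 2 (0.11 log units; within the scatter), which lies within the scatter. That step involves different groups from the ones exchanged here, so it only hints that changing the group on this nitrogen need not move the number much. Within the data shown here, no measured pair sets 3-chlorophenyl against 4-methylphenyl directly. On this basis the step is expected to be a 1.1-fold higher number from compound 3 to compound 4 (0.05 log units; within the scatter), not beyond the scatter in either direction. The estimate for compound 4 in this assay is 4000 nM, within a range from 1500 nM to 11000 nM.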

Compound 4, half-maximal inhibitory concentration: 3390 nM
Beside the measured number, compound 4's estimate is 1.2-fold (0.07 log units) above it; low and high end bracket the measured number.
By their numbers in this assay, from the lowest: compounds 4 and 3 (each within the scatter of the next); then compounds 1 and 2 (each within the scatter of the next).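

In this assay, a 1.1-fold lower number from compound 3 to compound 4 (0.02 log units; within the scatter), so a second pair of compounds now shows a swap of the group on this nitrogen that stays within the scatter, alongside a 1.3-fold higher number from compound 1 to compound 2 (0.11 log units; within the scatter). This swap alters two things at once, since 3-chlorophenyl carries a chlorine and 4-methylphenyl carries a methyl at a differently numbered ring carbon, and the pair cannot tell whether each change has little effect or whether two larger effects cancel. Nothing measured here explains why the number holds steady across this swap.

The compounds shown leave open how 4-chlorophenyl or 3-methylphenyl would compare on this nitrogen, and those two groups would help separate the kind of substituent from its place on the ring. They also leave open whether the tolerance seen so far extends to groups of a different kind, such as a phenyl ring bearing a carboxylic acid or an amine, or a longer carbon chain in place of the ring.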